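Shrinking a Cyclohexyl Amide to Isopropyl

This account rests on a few compounds, and the source may have more. Where it says the series, first, only, none or still open, it means among the compounds named here.

Compound 2 `Cc1cccc(Cn2c(CN3CCN(C(=O)C4CCCCC4)CC3)nc3ccccc32)c1` gives 31.9% in an assay on isolated protein for inhibition of aldehyde dehydrogenase 1A1 (Homo sapiens), read by spectrophotometry, tested at 10 uM (a lower number here means less inhibition, a higher number more inhibition at the concentration tested (going by the name of the read-out)), the second highest of three numbers. Compound 1 `Cc1cccc(Cn2c(OC3CCN(C(=O)c4ccco4)CC3)nc3ccccc32)c1` gives 68.3% and compound 3 `CC(C)CCn1c(OC2CCN(C(=O)c3ccco3)CC2)nc2ccccc21` gives 30.8%; compounds 2 and 3 lie within the scatter of each other, while compound 1 sits well above both. Within the data shown here, the only measured step, a number 37.5 percentage points lower from compound 1 to compound 3 (beyond the scatter), changes the group on the saturated chain carbon bound to the aromatic nitrogen, not the amide end, so it does not bear on the present change. Compound 4 `Cc1cccc(Cn2c(CN3CCN(C(=O)C(C)C)CC3)nc3ccccc32)c1` differs from compound 2 by isopropyl in place of cyclohexyl on a carbonyl carbon. Among the measured compounds shown here, with no measured step at this position, no step beyond the scatter is expected. Compound 4 is therefore estimated at 30%, ranging from 15% to 48%. The expected step is a number 1.9 percentage points lower from compound 2 to compound 4 (within the scatter).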

Compound 4, a percentage reported as inhibition, at one concentration (the size of the read-out at that concentration, not a potency): 87.2%
Compound 4: middle estimate off by 57.2 percentage points, on the low side; the measured number lies above the stated range.
By their numbers in this assay, from the lowest: compounds 3 and 2 (each within the scatter of the next); then compound 1; then compound 4.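

At the amide end, swapping cyclohexyl for isopropyl on the carbonyl carbon in this assay produces a number 55.3 percentage points higher from compound 2 to compound 4 (beyond the scatter). This end of the molecule is therefore far from neutral, and a change of only a few carbon atoms there can strongly alter inhibition at the concentration tested. No measured evidence explains this jump. Among these compounds, with only this pair, the effect of losing the ring cannot be separated from that of losing carbon atoms. Cyclopropyl, tert-butyl or a longer chain such as n-butyl on the carbonyl carbon could help separate them.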